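A few compounds are considered here, and "the series" means these few. Any claim that something is new, unique, unknown or untested is made for them only; others in the source may bear on it.

Measured so far in a functional assay, with a stated time of 6 min; on this read-out lower numbers stand for stronger inhibition and higher numbers for weaker inhibition:
- Compound 1 `S=c1[nH]nc(-c2ccc3c(c2)OCCO3)o1`: 10600 nM
- Compound 2 `COc1ccc(NCn2nc(-c3ccc4c(c3)OCCO4)oc2=S)cc1`: 5830 nM
- Compound 3 `Fc1ccc(NCn2nc(-c3ccc4c(c3)OCCO4)oc2=S)cc1`: 6480 nM

Compound 3 cannot be told apart from compound 2 or from compound 1 on these numbers, as its gaps to both lie within the usual scatter of repeated measurements. Compound 1 lacks the substituted phenyl group altogether, yet even this large structural difference leaves it within the scatter of compound 3.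

Compound 4 `S=c1oc(-c2ccc3c(c2)OCCO3)nn1CNc1cccc(Cl)c1` has not yet been measured. It differs from compound 3 in one place: 3-chlorophenyl in place of 4-fluorophenyl on an amine nitrogen. Put simply, it has 3-chlorophenyl in place of 4-fluorophenyl on an amine nitrogen.

For the measured compounds named here, only one measured step bears directly on this change, as it also alters the group carried on that amine nitrogen. Fluoro in place of methoxy on an aromatic carbon gave a 1.1-fold higher number from compound 2 to compound 3 (0.05 log units; within the scatter). Going by the values given here, that is a single small step, and no measured compound carries 3-chlorophenyl, so the evidence is thin. No step beyond the scatter is therefore expected in this assay, and the data favour no direction.

The expected step is a 1.1-fold lower number from compound 3 to compound 4 (0.03 log units; within the scatter). For compound 4 the estimated value is 6000 nM, with an expected range of 2800 nM to 12000 nM.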

Compound 4, half-maximal inhibitory concentration: 6220 nM
Estimate against measurement, compound 4: 1.0-fold (0.02 log units) below, within the range that was stated.
By their numbers in this assay, from the lowest: compounds 2, 4, 3 and 1 (each within the scatter of the next).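

In this assay, for the compounds shown here, the exchange of 4-fluorophenyl for 3-chlorophenyl on the amine nitrogen produces no step that can be told from repeat-measurement noise (a 1.0-fold lower number from compound 3 to compound 4 (0.02 log units; within the scatter)), and the same holds for 3-chlorophenyl in place of 4-methoxyphenyl (a 1.1-fold higher number from compound 2 to compound 4 (0.03 log units; within the scatter)). Before this result, only the exchange between the 4-methoxyphenyl and 4-fluorophenyl groups had been seen, so compound 4 extends the finding to a different substituent, named at a different ring number, with compound 2, compound 3 and compound 4 all remaining within the scatter of one another. No measurement here accounts for why the number stays put across these three groups.

The compounds shown leave open whether any group on this phenyl ring can move the number beyond the scatter, for example a carboxylic acid, a basic amine or a nitrile. On these data alone, it is also open whether the phenyl ring itself is needed on the amine nitrogen, or whether a saturated ring or a longer alkyl chain in its place would give a clearly different reading.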